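The source may report more compounds than this note shows. Statements on the series, on what has been measured and on what is new or still open speak of the compounds shown alone.

Of the compounds shown here, two have been read so far in a physicochemical assay for lipophilicity, read by spectrophotometry, measured as octanol-water partition, at pH 7.4; on this read-out higher numbers stand for higher lipophilicity and lower numbers for lower lipophilicity. Compound 1 `CCOc1cc(CN2CCC(NC(=O)c3cncc(C)c3)CC2)cc(OCC)c1-c1ccc(F)cc1` gives 4.01. Compound 2 `CCOc1cc(CN2CCC(NC(=O)c3cncc(C)c3)CC2)ccc1C` gives 3.03, the lower of the two numbers, and its gap to compound 1 lies beyond the scatter. Still unmeasured is compound 3 `CCOc1cc(CN2CCC(NC(=O)c3cncc(C)c3)CC2)ccc1-c1ccc(F)cc1`, which has 4-fluorophenyl in place of methyl on an aromatic carbon of compound 2 (4-fluorophenyl in place of methyl on an aromatic carbon). For the measured compounds named here, no measured pair isolates this change. Going by the values given here, the only guide is compound 1, which also carries 4-fluorophenyl, along with a further ethoxy group, and stands at 4.01. An upward move beyond the scatter is therefore expected, ending near or somewhat short of that number. The expected move is a number 0.67 log units higher from compound 2 to compound 3 (beyond the scatter). In this assay, compound 3 is estimated at 3.7, with an expected range of 3.3 to 4.1.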

Compound 3, distribution coefficient: 4.1
The estimate for compound 3 lay 0.40 log units below the measured number, and the stated range covers the measured number.
By their numbers in this assay, from the lowest: compound 2; then compounds 1 and 3 (each within the scatter of the next).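

For the compounds shown here, replacing methyl with 4-fluorophenyl on this aromatic carbon, ortho to an ethoxy group and para to a large group, gives a number 1.07 log units higher from compound 2 to compound 3 (beyond the scatter) in this assay, the first reading of this change on its own and a large step. With 4-fluorophenyl in place, hydrogen in place of ethoxy gives a number 0.09 log units higher from compound 1 to compound 3 (within the scatter), so the further ethoxy group of compound 1 does not separate these two compounds on this read-out. No measured evidence accounts for the size of either step.

Only methyl and 4-fluorophenyl are shown at this carbon, so it remains open how an unsubstituted phenyl, a carboxylic acid or a primary amine there would read. Also open, from the compounds shown here alone, is whether a further ethoxy group would count for as little alongside methyl.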